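The source may report more compounds than this note shows. Statements on the series, on what has been measured and on what is new or still open speak of the compounds shown alone.

Of the compounds shown here, three of one shared core have been tested in a functional assay on A549 cells (Homo sapiens) for antiproliferative activity, read by XTT assay, with a stated time of 24 h; on this read-out lower numbers stand for stronger inhibition and higher numbers for weaker inhibition. Compound 1, `Cc1ccc(C2=NN(c3nc(-c4ccc(F)cc4)cs3)C(c3ccc(F)cc3)C2)s1`, gives 125 ug/mL. Compound 3, `Cc1ccc(C2=NN(c3nc(-c4ccc(Br)cc4)cs3)C(c3ccc(F)cc3)C2)s1`, reaches only the limit of the assay and returns > 500 ug/mL, a limit rather than a number. Compound 2, `Fc1ccc(C2CC(c3ccc(Cl)s3)=NN2c2nc(-c3ccc(C(F)(F)F)cc3)cs2)cc1`, likewise returns only the limit > 500 ug/mL. Compound 3 therefore stands at the weak end of what has been measured, beyond the highest concentration the assay resolves, as does compound 2, while compound 1 alone gives a real number.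

Within the data shown here, the one step measured within this set, an at least 4.0-fold higher number from compound 1 to compound 3 (0.60 log units; beyond the scatter), shows that enlarging the substituent on the phenyl ring from fluoro to bromo pushed the compound past the limit, and the limit of > 500 ug/mL in this assay, at which 2 of the 3 values shown sit, marks where this limit sits. Compound 4, `Cc1ccc(C2=NN(c3nc(-c4ccc(C(F)(F)F)cc4)cs3)C(c3ccc(F)cc3)C2)s1`, differs from compound 3 by trifluoromethyl in place of bromo on an aromatic carbon. Compound 2, which carries the same trifluoromethylphenyl group on a different thienyl partner, already sits at the limit.

Compound 4 is therefore expected to remain at or near the limit, with a step of a number no higher from compound 3 to compound 4 (the limit leaves the size open) from compound 3. The estimate for compound 4 in this assay is 500 ug/mL, with a range from 200 ug/mL to 1000 ug/mL.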

Compound 4, half-maximal inhibitory concentration: > 500 ug/mL
Compound 4 gave a limit, no number; the forecaster's own chance of this, stated with the estimate: 70%; the middle value sits exactly at the limit.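

In this assay, trifluoromethyl at this place on the phenyl ring, like bromo before it, moves the read-out away from that of the fluoro compound, with an at least 4.0-fold higher number from compound 1 to compound 4 (0.60 log units; beyond the scatter). Compound 4 returns only a limit, so among the three groups tried at this position, para to a large group, fluoro in compound 1 alone gives a real number: the limit of > 500 ug/mL in this assay, at which 3 of the 4 values shown sit. The steps from compound 3 to compound 4 and from compound 2 to compound 4 cannot be read, since both ends of each are limits, so bromo and trifluoromethyl cannot be ranked against each other.

Open, as far as these compounds go, is whether a plain hydrogen, a methoxy group or an amine at this place would give a real number. From the compounds shown here alone, it is also open whether any of them would give a lower number than compound 1.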